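The source may hold more compounds than are shown below. What is called first, only, known or untested is meant among the compounds shown, and "the series" means these compounds.

Compound 1 `CN(c1ccccc1CCCn1nnnc1[C@@H](COCc1ccccc1)NC(=O)C(C)(C)N)S(C)(=O)=O` was tested in an assay on isolated protein for displacement of a labelled ligand from growth hormone secretagogue receptor type 1 (Homo sapiens), with a stated time of 1 h (on this read-out lower numbers stand for stronger inhibition and higher numbers for weaker inhibition), and gave 1720 nM. A close relative, compound 2 `CC(C)(N)C(=O)N[C@H](COCc1ccccc1)c1nnn(CCCc2ccccc2NS(C)(=O)=O)n1`, gave 2390 nM in this assay. Compound 1 stands at one end of this pair of numbers and compound 2 at the other, yet the gap between them lies within the usual scatter of such measurements, so neither compound can be called the stronger binder.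

The next compound, compound 3 `COC(=O)CCCn1nnnc1[C@@H](COCc1ccccc1)NC(=O)C(C)(C)N`, keeps the core of compound 1 and changes one part: methoxycarbonyl in place of 2-(methyl(methylsulfonyl)amino)phenyl on a saturated chain carbon, three bonds along the chain from an aromatic nitrogen. Among the compounds with values here, no measured pair in this set shows what such a swap does, so the expectation rests on the structural change alone. The expected step in this assay is a 2.9-fold higher number from compound 1 to compound 3 (0.46 log units; beyond the scatter), toward weaker binding. On that basis compound 3 is estimated at 5000 nM, within a range from 1500 nM to 16000 nM.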

Compound 3, inhibition constant: 2380 nM
Compound 3: the middle estimate sits 2.1-fold (0.32 log units) above what was measured; low and high end bracket the measured number.
By their numbers in this assay, from the lowest: compounds 1, 3 and 2 (each within the scatter of the next).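

In this assay, putting methoxycarbonyl in place of 2-(methyl(methylsulfonyl)amino)phenyl on a saturated chain carbon, three bonds along the chain from an aromatic nitrogen, gives a 1.4-fold higher number from compound 1 to compound 3 (0.14 log units; within the scatter), so this swap has no effect that can be told from the scatter. The group that leaves has 12 heavy atoms and a six-membered aromatic ring, while the one that enters has 4 heavy atoms and no ring, so for this pair the ring is not required to hold the number at the level of compound 1. Nothing measured here gives a reason for this outcome.

The compounds shown do not tell whether any group at this place can move the number beyond the scatter. As far as these compounds go, whether a carboxylic acid, an amine or an unsubstituted phenyl there would behave like methoxycarbonyl stays open.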